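The source may report more compounds than this note shows. Statements on the series, on what has been measured and on what is new or still open speak of the compounds shown alone.

Compound 1: `S=c1[nH]nc(-c2ccncc2)n1-c1ccc2ncccc2c1`, with 15000 nM in a physicochemical assay for solubility; a higher number here means a more soluble compound, a lower number a less soluble compound. Compound 2: `Nc1cc(-c2n[nH]c(=S)n2-c2ccc3ccccc3c2)ccn1`, with 100000 nM in this assay.

Compound 2 holds the higher of the two numbers in this assay, and compound 1 sits a good way below it, beyond the scatter. Compound 3 is `Fc1cnccc1-c1n[nH]c(=S)n1-c1ccc2ccccc2c1`; its difference from compound 2 is 3-fluoropyridin-4-yl in place of 2-aminopyridin-4-yl on an aromatic carbon. Within the data shown here, no measured pair shows this exact change, so the size of the step is uncertain. A decrease in this assay that goes beyond the scatter is expected, with compound 3 estimated at 20000 nM, within 5000 nM to 80000 nM, a step from compound 2 to compound 3 of a 5.0-fold lower number from compound 2 to compound 3 (0.70 log units; beyond the scatter).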

Compound 3, solubility: 35000 nM
Estimate against measurement, compound 3: 1.8-fold (0.24 log units) below; the measured number falls inside the stated range.
By their numbers in this assay, from the lowest: compound 1; then compound 3; then compound 2.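

At this aromatic carbon, between two ring nitrogen atoms, putting 3-fluoropyridin-4-yl in place of 2-aminopyridin-4-yl gives a 2.9-fold lower number from compound 2 to compound 3 (0.46 log units; beyond the scatter) in this assay, a modest step. This single pair cannot separate the loss of the amino group from the gain of the fluorine. Nothing at hand bears on the reason for the step. The compounds shown leave open how an unsubstituted pyridin-4-yl would stand at this position, and whether a methoxy or dimethylamino group in place of the amino group would keep the higher number.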